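Lengthening the side chain of compound 1 toward a plain alkyl

The source may report more compounds than this note shows. Statements on the series, on what has been measured and on what is new or still open speak of the compounds shown alone.

Compound 1, `O=c1cc(Cn2cc(CCCCl)nn2)c2ccc(O)cc2o1`, is the only one of the three measured compounds that yields an actual number in a functional assay on SW-620 cells (Homo sapiens) for inhibition, read by MTT assay, with a stated time of 72 h; a lower number here means a stronger inhibitor, a higher number a weaker inhibitor: compound 1 reaches 59800 nM. Compound 2, `O=c1cc(Cn2cc(CCO)nn2)c2ccc(O)cc2o1`, carries a hydroxy in place of the chloromethyl of compound 1 on a saturated chain carbon, two bonds along the chain from an aromatic carbon. In this assay compound 2 is reported only as a limit, > 100000 nM. Compound 3, `CC(C)(C)c1cn(Cc2cc(=O)oc3cc(O)ccc23)nn1`, has a tert-butyl in place of the 3-chloropropyl on an aromatic carbon, and compound 3 likewise sits at a limit, > 100000 nM. Both changes therefore give an at least 1.6-fold higher number from compound 1 to compound 2 (0.22 log units; that floor lies within the scatter) and an at least 1.6-fold higher number from compound 1 to compound 3 (0.22 log units; that floor lies within the scatter), and the limit of > 100000 nM in this assay, at which 2 of the 3 values shown sit, hides how large those steps really are.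

Compound 4, `CCCCCCc1cn(Cc2cc(=O)oc3cc(O)ccc23)nn1`, differs from compound 1 by propyl in place of chloro on a saturated chain carbon, three bonds along the chain from an aromatic carbon. Neither measured step repeats this exactly; the closest is the move to a group made only of carbon in compound 3, which ended at a limit. The expectation for compound 4 is a 1.4-fold higher number from compound 1 to compound 4 (0.15 log units; within the scatter), a change that may stay within the scatter or run into the limit. Compound 4 is estimated at 85000 nM, within 30000 nM to 250000 nM.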

Compound 4, half-maximal inhibitory concentration: > 100000 nM
Compound 4: only a limit was reported; the forecaster's own chance of this, stated with the estimate: 45%; at least 1.1-fold (0.07 log units) between middle value and limit.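

Replacing the chloro of compound 1 with propyl, which turns 3-chloropropyl into hexyl, gives an at least 1.6-fold higher number from compound 1 to compound 4 (0.22 log units; that floor lies within the scatter), so in this assay a straight chain made only of carbon ends at a limit, as the tert-butyl of compound 3 did. Compound 1 therefore remains the only one of the four with an actual number, although that floor does not separate compound 4 from compound 1 beyond the usual scatter, and so the chloro cannot yet be credited with any effect. The steps from compound 2 and compound 3 to compound 4 cannot be read, and this position now offers little room for comparison: the limit of > 100000 nM in this assay, at which 3 of the 4 values shown sit.

As far as these compounds go, how far compound 4 really lies from compound 1 stays open, as does any ranking among compound 2, compound 3 and compound 4. Also open, from the compounds shown here alone, is what an amine or a carboxylic acid in place of the chloro of compound 1, or a chain longer than hexyl, would give in this assay.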